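Pyridin-3-yl in place of thiophen-3-yl in compound 2

The source may report more compounds than this note shows. Statements on the series, on what has been measured and on what is new or still open speak of the compounds shown alone.

Compound 1 `Oc1cccc(-c2cc(-c3ccccc3)cc(-c3ccsc3)n2)c1`: 75.8%
Compound 2 `Oc1ccc(-c2cc(-c3ccccc3)cc(-c3ccsc3)n2)cc1`: 20.4%
Compound 3 `Oc1ccc(-c2cc(-c3ccccc3)cc(-c3cccnc3)n2)cc1`: not yet measured

In an assay on isolated protein for inhibition of DNA topoisomerase 1 (Homo sapiens), with a stated time of 30 min, tested at 100 uM (on this read-out lower numbers stand for a weaker effect and higher numbers for a stronger effect at the one concentration tested), compound 1 gives 75.8%, while compound 2 gives 20.4%, the lower of the two numbers. Going by the values given here, the single step measured so far, a number 55.4 percentage points lower from compound 1 to compound 2 (beyond the scatter), swaps 3-hydroxyphenyl for 4-hydroxyphenyl and lies beyond the scatter. Compound 3 differs from compound 2 in a different place: pyridin-3-yl in place of thiophen-3-yl on an aromatic carbon. Among the compounds with values here, no measured step bears on this exchange of thiophen-3-yl for pyridin-3-yl; the hydroxyphenyl step concerns another part of the molecule and gives no guide here. With nothing to lean on, the expected step of a number 1.6 percentage points higher from compound 2 to compound 3 (within the scatter) in this assay is none beyond the scatter, in either direction. Compound 3 is therefore estimated at 22%, with a range from 5% to 50% that reflects this lack of any relevant comparison.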

Compound 3, a percentage reported as inhibition, at one concentration (the size of the read-out at that concentration, not a potency): 44%
Compound 3: the middle estimate sits 22 percentage points below what was measured; measured number inside the range.
By their numbers in this assay, from the lowest: compound 2; then compound 3; then compound 1.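

In this assay, pyridin-3-yl in place of thiophen-3-yl gives a number 23.6 percentage points higher from compound 2 to compound 3 (beyond the scatter), so the group on this aromatic carbon, next to the ring nitrogen, also affects the read-out, while the 4-hydroxyphenyl group stays unchanged. The earlier pair had shown a change only in the hydroxyphenyl group; this exchange replaces a five-membered aromatic ring bearing sulfur with a six-membered aromatic ring bearing nitrogen, so the step cannot be assigned to ring size or to the hetero atom alone. No measurement here accounts for the higher number.

The compounds shown leave open whether the same exchange would change the read-out with the 3-hydroxyphenyl group of compound 1 in place. They also leave open how an amine or a carboxylic acid would read at this position.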